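This account rests on a few compounds, and the source may have more. Where it says the series, first, only, none or still open, it means among the compounds named here.

Of the compounds shown here, two have so far been tested in a functional assay, with a stated time of 20 min, tested at 2 uM; on this read-out higher numbers stand for a stronger effect at the one concentration tested and lower numbers for a weaker effect. Compound 1 `COc1cc(/C=C/C(=O)C2=C(/C=C/c3ccc(O)c(OC)c3)NC(=O)NC2c2cccc([N+](=O)[O-])c2)ccc1O` gives 10.2% in this assay. Among the measured compounds shown here, compound 2 `COc1cc(/C=C/C(=O)C2=C(/C=C/c3ccc(O)c(OC)c3)NC(=S)NC2c2ccc(C)cc2)ccc1O` differs from compound 1 in more than one place, so no single step between them is counted; in this assay compound 2 gives 10.2%, level with compound 1 within the scatter. For the measured compounds named here, compound 3 `COc1cc(/C=C/C(=O)C2=C(/C=C/c3ccc(O)c(OC)c3)NC(=S)NC2c2c(Cl)cccc2Cl)ccc1O` has not yet been measured. 2,6-dichlorophenyl in place of 4-methylphenyl on a saturated ring carbon The group that leaves and the group that enters each carry no hydrogen-bond donors and no hydrogen-bond acceptors, and no step is on record for any change of this kind. The change is therefore expected to bring no step beyond the scatter, because compound 2 sits at 10.2% alongside compound 1 with a different group. Compound 3 is estimated at 11%, within a range from 2% to 25%. That estimate means an expected step of a number 0.8 percentage points higher from compound 2 to compound 3 (within the scatter).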

Compound 3, a percentage reported as activity, at one concentration (the size of the read-out at that concentration, not a potency): 15%
Beside the measured number, compound 3's estimate is 4 percentage points below it; low and high end bracket the measured number.
By their numbers in this assay, from the lowest: compounds 1, 2 and 3 (each within the scatter of the next).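

In this assay, placing 2,6-dichlorophenyl where 4-methylphenyl stood on the saturated ring carbon brings a number 4.8 percentage points higher from compound 2 to compound 3 (within the scatter). Among the compounds shown here, this is the first step that can be read at this position, and it shows that this exchange of one aromatic ring for another, with both rings carrying no hydrogen-bond donors or acceptors, produces no change beyond the scatter. Nothing available explains the size of this step or says how the two groups act at this position.

On these data alone, it remains open whether a phenyl ring bearing an amine or a carboxylic acid, or a longer chain in place of the ring, would move the number beyond the scatter at this position. For the compounds shown here, no pair differing in one place isolates the exchange of the carbonyl for a thiocarbonyl in the shared core, so that change also remains unread.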